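Chloro to trifluoromethyl on the anilino ring of compound 2

A few compounds are considered here, and "the series" means these few. Any claim that something is new, unique, unknown or untested is made for them only; others in the source may bear on it.

Compound 1, `CC(C)c1ccc(-c2nc(SCc3cn(CC(=O)NC(=O)Nc4ccccn4)nn3)nc(Nc3cccc(C(F)(F)F)c3)c2C#N)cc1`, in a functional assay on ECa-109 cells (Homo sapiens) for inhibition, read by MTT assay, with a stated time of 72 h; on this read-out higher numbers stand for weaker inhibition and lower numbers for stronger inhibition: 24200 nM
Compound 2, `Cc1ccc(-c2nc(SCc3cn(CC(=O)NC(=O)Nc4ccccn4)nn3)nc(Nc3cccc(Cl)c3)c2C#N)cc1`, in this assay: 25600 nM

Compound 2 carries the highest of the two numbers, but its nearest neighbour, compound 1, gives a value that lies within the scatter of repeated measurements, so the two compounds cannot be told apart on this assay. Compound 3, `Cc1ccc(-c2nc(SCc3cn(CC(=O)NC(=O)Nc4ccccn4)nn3)nc(Nc3cccc(C(F)(F)F)c3)c2C#N)cc1`, has not been measured. It differs from compound 2 in one place: trifluoromethyl in place of chloro on an aromatic carbon. For the measured compounds named here, no measured pair isolates this change, so there is no step to lean on. Both measured compounds, one bearing chloro and one bearing trifluoromethyl on the anilino ring, sit at nearly the same value, which suggests the change matters little here. The step from compound 2 to compound 3 is expected to be a 1.1-fold lower number from compound 2 to compound 3 (0.05 log units; within the scatter), within the scatter. Compound 3 is therefore estimated at 23000 nM, with a range from 9000 nM to 60000 nM.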

Compound 3, half-maximal inhibitory concentration: 32300 nM
Beside the measured number, compound 3's estimate is 1.4-fold (0.15 log units) below it, within the range that was stated.
By their numbers in this assay, from the lowest: compounds 1, 2 and 3 (each within the scatter of the next).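

In this assay, the change from chloro to trifluoromethyl on this aromatic carbon now has a step of its own: a 1.3-fold higher number from compound 2 to compound 3 (0.10 log units; within the scatter). Going from one heavy atom to four at this position therefore produces no readable change in the value. The second step shows the same for the other substituent, with methyl in place of isopropyl on an aromatic carbon giving a 1.3-fold higher number from compound 1 to compound 3 (0.13 log units; within the scatter), and nothing available bears on either step.

The compounds shown carry only chloro or trifluoromethyl at this position, so it remains open whether an amine, a carboxylic acid or a methoxy group there would move the value beyond the scatter. They also carry only methyl or isopropyl at the other site, leaving open what a longer chain or a hydroxyl group would do there.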